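This account rests on a few compounds, and the source may have more. Where it says the series, first, only, none or still open, it means among the compounds named here.

Compound 1 `CC1(/C=C/c2ccccc2C(F)(F)F)C=CC(=O)O1`: 27900 nM
Compound 2 `CC1(/C=C/c2ccccc2O)C=CC(=O)O1`: 136000 nM

Within the data shown here, in a functional assay on 786-0 cells (Homo sapiens) for inhibition, read by sulforhodamine B assay, with a stated time of 48 h (a lower number here means a stronger inhibitor of growth, a higher number a weaker inhibitor of growth), compound 2 gives 136000 nM, the highest number so far, which makes it the weaker growth inhibitor of the pair. Compound 3 `COc1ccccc1/C=C/C1(C)C=CC(=O)O1` makes one change to compound 2: methyl in place of hydrogen on an oxygen on an aromatic ring, which is hydroxy to methoxy, with methyl in place of hydrogen on an oxygen on an aromatic ring.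

Among the measured compounds shown here, no measured step shows this exact change. The closest evidence is a 4.9-fold higher number from compound 1 to compound 2 (0.69 log units; beyond the scatter), a modest step that also involves the hydroxy group. That single step suggests that replacing the hydroxy group can alter the number, and compound 1, at 27900 nM, shows a lower value without it. The expected change is therefore modest and downward, namely a 2.2-fold lower number from compound 2 to compound 3 (0.34 log units; beyond the scatter). For compound 3, the estimated value is 62000 nM, with an expected range of 22000 nM to 160000 nM.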

Compound 3, concentration for total growth inhibition: 35400 nM
Beside the measured number, compound 3's estimate is 1.8-fold (0.24 log units) above it, and the stated range covers the measured number.
By their numbers in this assay, from the lowest: compounds 1 and 3 (each within the scatter of the next); then compound 2.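

In this assay, putting methyl on the oxygen on the aromatic ring gives a 3.8-fold lower number from compound 2 to compound 3 (0.58 log units; beyond the scatter) and so a stronger inhibitor of growth. This shows that the hydrogen on that oxygen is not needed for growth inhibition, and that a small change at this one atom is enough to move the number. Methoxy and trifluoromethyl, two quite different groups, give a 1.3-fold higher number from compound 1 to compound 3 (0.10 log units; within the scatter) and cannot be told apart here, so among these three compounds only the hydroxy compound, compound 2, stands apart.

Going by these compounds, whether a longer chain on this oxygen, such as ethyl, or an amine in place of the oxygen would hold the number near that of compound 3 remains open. No measurement shown gives a reason for these differences.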